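Swapping Prop-1-en-1-yl for Methyl in Compound 4

The source may report more compounds than this note shows. Statements on the series, on what has been measured and on what is new or still open speak of the compounds shown alone.

Of the compounds shown here, three have been measured in a functional assay on HeLa cells (Homo sapiens) for cytotoxicity (a lower number here means a stronger inhibitor, a higher number a weaker inhibitor), and their numbers give a first sense of scale. Compound 2 `C/C=C/C(=O)OC1=CC(=O)c2ccccc2C1=O` gives 37900 nM. Compound 3 `C=CCOc1ccc2c(c1)C(=O)C=CC2=O` gives 27200 nM, which lies within the scatter of compound 2. Compound 1 `Cc1ccc(S(=O)(=O)Oc2cccc3c2C(=O)C=CC3=O)cc1` gives 9470 nM, a lower number that stands apart from compound 2 by more than the scatter, so compound 2 is the weaker inhibitor of that pair.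

The next compound to be tested is compound 4 `CC(=O)OC1=CC(=O)c2ccccc2C1=O`. It has methyl in place of the prop-1-en-1-yl of compound 2, on a carbonyl carbon, so that (prop-1-en-1-yl)carbonyl becomes acetyl (methyl in place of prop-1-en-1-yl on a carbonyl carbon). The rest of the structure stays the same.

Among the compounds with values here, no two measured compounds differ in one place only, so the data give no direct guide to the effect of this change. The best starting point is compound 2 itself, at 37900 nM in this assay. With so little to go on, no shift beyond the scatter is expected, and any small move is tentatively expected toward a lower number. The expected step, a 1.5-fold lower number from compound 2 to compound 4 (0.18 log units; within the scatter), is therefore modest. For compound 4 the estimated value is 25000 nM, with an expected range from 9000 nM to 70000 nM.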

Compound 4, half-maximal inhibitory concentration: 62100 nM
Estimate against measurement, compound 4: 2.5-fold (0.40 log units) below; the range from low to high includes it.
By their numbers in this assay, from the lowest: compound 1; then compounds 3, 2 and 4 (each within the scatter of the next, the first and the last beyond it).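

Within the data shown here, replacing prop-1-en-1-yl with methyl on a carbonyl carbon is the first change in this set that alters a single place, and in this assay it gives a 1.6-fold higher number from compound 2 to compound 4 (0.21 log units; within the scatter). At this position, then, going from a group of 3 heavy atoms with a double bond outside any ring to methyl, with 1 heavy atom, leaves the two compounds indistinguishable. A step this size lies within the scatter of repeated measurements. This suggests that neither the length of this small group nor its double bond has a clear effect on the read-out here, although no separate measurement bears on why that is.

On these data alone, whether a much longer chain, a phenyl ring or an amine on this same carbonyl carbon would shift the number beyond the scatter remains open, as the two groups compared here are both small hydrocarbon groups. Compound 1 and compound 3 each differ from compound 4 in more than one place, so their steps cannot be read, and what sets compound 1 apart in this assay remains unresolved.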